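The compounds below may be only part of what the source reports. "The series", "measured", "known", "first", "only" and "open" are said of these compounds alone.

Compound 1 `CC(=O)N1N=C(c2ccc(-n3c(C)ccc3C)cc2)OC1c1ccc(Br)cc1` was examined in an ADME assay on Vero cells (Chlorocebus sabaeus) for cytotoxicity, read by MTT assay, with a stated time of 72 h (a lower number here means a stronger inhibitor, a higher number a weaker inhibitor), where compound 1 gives 195000 nM. Compound 3 `c1ccc(-c2nnc(-c3ccc(-n4cccc4)cc3)o2)cc1` gives 250000 nM in this assay, and the two numbers lie within the usual scatter of each other, so neither can be called weaker or stronger. Compound 2 `Cc1ccc(C)n1-c1ccc(C(=O)N/N=C/c2ccc(O)cc2)cc1` gives "not determined" (no result reported) in this assay, so it adds nothing to the comparison. Compound 4 `CC(=O)N1N=C(c2ccc(-n3c(C)ccc3C)cc2)OC1c1cccc([N+](=O)[O-])c1` is yet to be measured. It differs from compound 1 in one place: 3-nitrophenyl in place of 4-bromophenyl on a saturated ring carbon. Within the data shown here, no measured pair in this set shares this kind of change, so there is nothing to show its size or direction here. Compound 4 is therefore expected to land close to compound 1, with a step of a 1.0-fold higher number from compound 1 to compound 4 (0.01 log units; within the scatter) that should not exceed the scatter, at an estimated 200000 nM and a range from 80000 nM to 500000 nM.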

Compound 4, half-maximal inhibitory concentration: 188000 nM
The estimate for compound 4 lay 1.1-fold (0.03 log units) above the measured number, and the stated range covers the measured number.
By their numbers in this assay, from the lowest: compounds 4, 1 and 3 (each within the scatter of the next).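

Among these compounds, putting 3-nitrophenyl in place of 4-bromophenyl on the saturated ring carbon gives, in this assay, a 1.0-fold lower number from compound 1 to compound 4 (0.02 log units; within the scatter) and offers the first reading of a change at this position. Two phenyl groups with different substituents in different places therefore cannot be told apart here, so this one swap leaves the reading in this assay unmoved. No measurement at hand explains this result. On these data alone, whether the same holds for a carboxylic acid or an amine on this phenyl ring remains open. Also open, as far as these compounds go, is what a longer chain in place of the acetyl group would do.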